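N-acyl chain extension on a bis(trifluoromethyl)anilide

The source may hold more compounds than are shown below. What is called first, only, known or untested is meant among the compounds shown, and "the series" means these compounds.

Measured so far:
compound 1 `CC(=O)N1c2ccccc2CCC1C(=O)Nc1cc(C(F)(F)F)cc(C(F)(F)F)c1`: > 70000 nM
compound 2 `O=C(Nc1ccccc1C(F)(F)F)C1CCc2ccccc2N1`: 53300 nM

The read-out throughout is a functional assay on PC-3 cells (Homo sapiens) for cytotoxicity, read by sulforhodamine B assay, with a stated time of 72 h; on this read-out higher numbers stand for weaker inhibition of growth and lower numbers for stronger inhibition of growth. Compound 1 gives only a limit, (the limit of > 70000 nM in this assay, at which 1 of the 2 values shown sits), so no number is known for it. Going by the values given here, compound 2 gives 53300 nM in this assay, a number and not a limit, but no single-point step links it to compound 1 and the two are not compared further here.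

Compound 3 `CCCCCCCCC(=O)N1c2ccccc2CCC1C(=O)Nc1cc(C(F)(F)F)cc(C(F)(F)F)c1` is not yet measured. It differs from compound 1 by heptyl in place of hydrogen on a saturated chain carbon bound to a carbonyl carbon. Among the compounds with values here, no measured step shows what such a change does, so the expectation rests on the limit of compound 1 alone. A step of an at least 2.3-fold lower number from compound 1 to compound 3 (0.36 log units; beyond the scatter) towards stronger inhibition of growth is expected, of modest size and possibly not beyond the scatter. Compound 3 is estimated at 30000 nM in this assay, within 6000 nM to 70000 nM, with a fair chance that only a limit is reported again.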

Compound 3, concentration for 50% growth inhibition: 7430 nM
Compound 3: the middle estimate sits 4.0-fold (0.61 log units) above what was measured; low and high end bracket the measured number.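

In this assay the series now has its first step at this position: heptyl in place of hydrogen on a saturated chain carbon bound to a carbonyl carbon gives an at least 9.4-fold lower number from compound 1 to compound 3 (0.97 log units; beyond the scatter) towards stronger inhibition of growth. Octylcarbonyl in place of acetyl thus turns a limit into a number, and this position accepts a chain of this length without loss of growth inhibition. Compound 1 has only a limit, so the step gives a lower bound on the change and not its full size: the limit of > 70000 nM in this assay, at which 1 of the 3 values shown sits.

With only acetyl and octylcarbonyl at this place, the compounds shown give no trend with chain length, and a butyl or a dodecyl chain would test one. Also open, going by these compounds, is whether an amine or a carboxylic acid at the end of the chain keeps the step.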